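From Phenyl to 4-Methylbenzyl on an Amide Nitrogen

The compounds below may be only part of what the source reports. "The series", "measured", "known", "first", "only" and "open" are said of these compounds alone.

In a functional assay on K562 cells (Homo sapiens) for cytotoxicity, read by MTT assay, with a stated time of 48 h (a lower number here means a stronger inhibitor, a higher number a weaker inhibitor), compound 1 (`COc1cc([C@@H]2C[C@@]2(CO)C(=O)Nc2ccccc2)cc(OC)c1OC`) gives > 100000 nM, which is a limit of the assay and not a number. Compound 2 (`CCOC(=O)C1(C(=O)Nc2ccc(F)cc2)CC1c1cc(OC)c(OC)c(OC)c1`) gives 63700 nM; > 100000 nM (2 entries) across its several entries.

Compound 3 (`COc1cc([C@@H]2C[C@@]2(CO)C(=O)NCc2ccc(C)cc2)cc(OC)c1OC`) differs from compound 1 by one change, (4-methylbenzyl in place of phenyl on an amide-type nitrogen), with 4-methylbenzyl in place of phenyl on an amide-type nitrogen. For the measured compounds named here, no measured step between these compounds shows what such a change does in this assay. Going by the values given here, compound 2, at 63700 nM; > 100000 nM (2 entries), offers the only number so far, and it points to weak inhibition for compound 3 as well. The expected step of an at least 1.4-fold lower number from compound 1 to compound 3 (0.15 log units; that floor lies within the scatter) is small and leans towards a stronger inhibitor. For compound 3 the estimated value is 70000 nM, with an expected range from 20000 nM to 150000 nM.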

Compound 3, half-maximal inhibitory concentration: > 100000 nM
Compound 3 ended at the assay's limit (the forecaster's own chance of this, stated with the estimate: 55%); middle value at least 1.4-fold (0.15 log units) from the limit.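

In this assay compound 3 gives > 100000 nM, which is a limit of the assay and not a number. Compound 1 also stands at a limit, so the step between compound 1 and compound 3 cannot be read. The compounds shown leave open whether 4-methylbenzyl in place of phenyl on an amide-type nitrogen changes the cytotoxicity at all.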